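Bromo to chloro among compounds at a limit

The source may hold more compounds than are shown below. What is called first, only, known or untested is meant among the compounds shown, and "the series" means these compounds.

Compound 1 `CC(C)c1ccc(C(Nc2ccc(C3(C)NC(=O)c4ccccc4N3)cc2)c2nnnn2C2CCCCC2)cc1`, compound 2 `CC1(c2ccc(NC(c3ccc(Cl)cc3)c3nnnn3C(C)(C)C)cc2)NC(=O)c2ccccc2N1` and compound 3 `CC1(c2ccc(NC(c3ccc(Br)cc3)c3nnnn3C3CCCCC3)cc2)NC(=O)c2ccccc2N1` were tested in an ADME assay on Vero cells (Chlorocebus sabaeus) for cytotoxicity, read by MTT assay, with a stated time of 72 h; on this read-out lower numbers stand for higher toxicity in this test and higher numbers for lower toxicity in this test. Compound 1 gives only a limit, > 400000 nM. Compound 2, which also carries chloro, gives only a limit, > 400000 nM. Compound 3 likewise gives only a limit, > 400000 nM, and so stands with the others: the limit of > 400000 nM in this assay, at which 3 of the 3 values shown sit. Compound 4 `CC1(c2ccc(NC(c3ccc(Cl)cc3)c3nnnn3C3CCCCC3)cc2)NC(=O)c2ccccc2N1` has chloro in place of bromo on an aromatic carbon, para to a large group: chloro in place of bromo on an aromatic carbon. Among the measured compounds shown here, the one measured step that bears on this is a step that the two limits leave unreadable from compound 1 to compound 3, bromo in place of isopropyl. Since a step that the two limits leave unreadable from compound 1 to compound 3 offers no size, no step beyond the scatter is expected in this assay. The expected step is a number no higher from compound 3 to compound 4 (the limit leaves the size open). Compound 4 is estimated at 400000 nM, with an expected range of 200000 nM to 800000 nM.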

Compound 4, half-maximal cytotoxic concentration: > 400000 nM
Compound 4: no number, only a limit; the forecaster's own chance of this, stated with the estimate: 85%; the middle value sits exactly at the limit.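

In this assay no step can be read among compound 1, compound 2, compound 3 and compound 4: the limit of > 400000 nM in this assay, at which 4 of the 4 values shown sit.

Whether exchanging bromo, chloro, isopropyl, tert-butyl or cyclohexyl changes the half-maximal cytotoxic concentration in this assay stays open among the compounds shown.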